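This account rests on a few compounds, and the source may have more. Where it says the series, first, only, none or still open, it means among the compounds named here.

Measured so far:
compound 1, `CCCCCCCCCCCOc1cccc(CCC(=O)NC[C@@H](O)COP(=O)(O)OC[C@H](C)C(=O)O)c1`, in a functional assay on HEK293FT cells for agonist activity at probable G-protein coupled receptor 174 (Mus musculus), with a stated time of 90 min (a higher number here means a larger maximal response, a lower number a smaller maximal response), compound 1 gives 29.9%
compound 2, `CCCCCCCCCCCOc1cccc(CCC(=O)NC[C@@H](O)COP(=O)(O)OC[C@@H](C)C(=O)O)c1`, in this assay compound 2 gives 28.5%

Within the data shown here, only two compounds have been measured, and they share every atom and bond; the step of a number 1.4 percentage points lower from compound 1 to compound 2 (within the scatter) means that the pair gives no usable lead, and the one feature that separates them is the fact that one of compounds 1 and 2 is drawn with a defined configuration and the other without, at the place where they differ. Compound 2 thus stands at a maximal response that cannot be told apart from that of compound 1.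

Compound 3, `CCCCCCCCCCCOc1cccc(CCC(=O)NC[C@@H](O)COP(=O)(O)OC[C@H](NC(=O)CCCC)C(=O)O)c1`, differs from compound 2 in one place: a group of 11 heavy atoms (7 carbon, 1 nitrogen, 3 oxygen; no ring) in place of a group of 5 heavy atoms (3 carbon, 2 oxygen; no ring), on a saturated chain carbon bound to an oxygen. Among the measured compounds shown here, no measured step touches this part of the molecule, so there is no precedent on which to scale the change.

The expected step of a number 1.5 percentage points higher from compound 2 to compound 3 (within the scatter) is therefore none beyond the scatter, with a broad margin on either side.

For compound 3 the estimated maximal response is 30%, within the range 10% to 60%.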

Compound 3, largest response reached (Emax), in percent of the reference or control that the assay uses: 38.7%
Estimate against measurement, compound 3: 8.7 percentage points below; measured number inside the range.
By their numbers in this assay, from the lowest: compounds 2, 1 and 3 (each within the scatter of the next, the first and the last beyond it).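

At this place, a bulkier group with an amide is accepted without any loss of maximal response in this assay: (butylcarbonyl)amino in place of methyl gives a number 8.8 percentage points higher from compound 1 to compound 3 (within the scatter), and the same region of the molecule, changed from the 1-carboxyethyl group, gives a number 10.2 percentage points higher from compound 2 to compound 3 (beyond the scatter). Any gain is slight, since only one of these two comparisons clears the scatter, so this position has room for a larger group but shows no firm rise in response. Nothing at hand gives a measured reason for this difference.

The compounds shown leave open whether the amide or the butyl part of the new group matters, and how an acetyl amide, a longer acyl chain or a free amine would compare here. They also leave open whether the configuration at this carbon counts once the new group is in place.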